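The source may report more compounds than this note shows. Statements on the series, on what has been measured and on what is new or still open speak of the compounds shown alone.

Measured in a functional assay on the whole organism (strain DBA/2) with Mus musculus as the target; on this read-out lower numbers stand for an effect already at smaller amounts and higher numbers for an effect only at larger amounts of compound:
- compound 1 `COc1cc2c(cc1OC)C(c1cccc([N+](=O)[O-])c1)N(C(=O)CN1CCCCC1)CC2`: > 100 umol/kg
- compound 2 `COc1cc2c(cc1OC)C(c1ccc(N)cc1)=NNC(=O)C2`: 15 umol/kg

Compound 1 gives > 100 umol/kg, which is a limit of the assay and not a number. It stands at the limit of > 100 umol/kg in this assay, at which 1 of the 2 values shown sits.

Compound 3 `COc1cc2c(cc1OC)C(c1cccc(N)c1)N(C(=O)CN1CCCCC1)CC2` keeps the core of compound 1 and changes one place, (amino in place of nitro on an aromatic carbon). This puts amino in place of nitro on an aromatic carbon, turning 3-nitrophenyl into 3-aminophenyl.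

Among the compounds with values here, no measured pair shows this change directly. Within the data shown here, the only guide is compound 2, which also bears an amino group on an aromatic carbon and gives 15 umol/kg, but its structure differs from compound 1 elsewhere too. In this assay, a clear but uncertain shift towards smaller doses is therefore expected. The estimated step is an at least 1.6-fold lower number from compound 1 to compound 3 (0.22 log units; that floor lies within the scatter).

Compound 3 is expected at 60 umol/kg, with an estimated range from 20 umol/kg to 150 umol/kg.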

Compound 3, dose for half-maximal effect: 70.2 umol/kg
Compound 3: the middle estimate sits 1.2-fold (0.07 log units) below what was measured, and the stated range covers the measured number.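

In this assay compound 3, with its 3-aminophenyl group, gives a real number, 70.2 umol/kg, which shows that with amino at this place the read-out comes within reach of the assay. Compound 1 gives > 100 umol/kg, which is a limit of the assay and not a number. The change can therefore be read only as a floor, an at least 1.4-fold lower number from compound 1 to compound 3 (0.15 log units; that floor lies within the scatter), and its true size stays open because compound 1 sits at that limit: the limit of > 100 umol/kg in this assay, at which 1 of the 3 values shown sits.

The compounds shown leave open how other groups at this place, such as a hydroxyl, a methoxy or an acetylamino group, would read in this assay. They also leave open whether a carboxylic acid or a longer chain carrying an amine would go further than amino does here.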